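The compounds below may be only part of what the source reports. "The series", "measured", "known", "first", "only" and "open" are said of these compounds alone.

Of the compounds shown here, two have so far been tested in a functional assay on the whole organism with Rattus norvegicus as the target, at a dose of 3 mg/kg by the oral route; on this read-out higher numbers stand for a stronger effect at the one dose given and lower numbers for a weaker effect. Compound 1 `O=C(Nc1nn[nH]n1)c1cc(Cl)cc(-c2ccc(Cl)cc2)n1` gives 11%. Within the data shown here, compound 2 `CCCCc1ccc(-c2cc(Cl)cc(C(=O)Nc3nn[nH]n3)n2)cc1` gives 83%, which is the highest of the two numbers; the only other compound, compound 1, lies well below it. Among the measured compounds shown here, the single measured step, a number 72 percentage points higher from compound 1 to compound 2 (beyond the scatter), is a large one and comes from butyl in place of chloro on an aromatic carbon of the outer ring.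

Compound 3 `CCCCc1ccc(-c2cc(CC)cc(C(=O)Nc3nn[nH]n3)n2)cc1` has not yet been measured. It differs from compound 2 by ethyl in place of chloro on an aromatic carbon. For the measured compounds named here, this change sits on a different ring from the one that was varied in the measured step, so no measured step bears directly on it, and swapping one small group for another at a place not yet varied gives no ground for expecting a shift beyond the scatter. Compound 3 is therefore expected to give about 75%, within a range from 45% to 95%. The step this implies, a number 8 percentage points lower from compound 2 to compound 3 (within the scatter), is expected to stay within the usual scatter.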

Compound 3, a percentage reported as inhibition, in the whole organism at one dose (the size of the read-out at that dose, not a potency): 70%
Compound 3: the middle estimate sits 5 percentage points above what was measured; low and high end bracket the measured number.
By their numbers in this assay, from the lowest: compound 1; then compound 3; then compound 2.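

Among these compounds, this is the first change at the position opposite the ring nitrogen, and it shows that the position is not indifferent to what sits there: ethyl in place of chloro gives a number 13 percentage points lower from compound 2 to compound 3 (beyond the scatter) in this assay. The step is modest, so chloro is not essential for a strong effect at this dose, as compound 3 still gives 70%. Nothing available on the properties of these compounds accounts for the step, so its cause remains unknown.

The compounds shown leave open whether the lower number goes with losing the chlorine or with gaining the two carbons of the ethyl. They also leave open how this position would respond to a methyl, to a longer chain such as propyl, or to an amine.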